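A Dichlorophenyl Swap With One Measured Anchor

A few compounds are considered here, and "the series" means these few. Any claim that something is new, unique, unknown or untested is made for them only; others in the source may bear on it.

Three compounds share one core: compound 1 (`COc1ccc(OCCCON2C(N)=NC(N)=NC23CCOCC3)cc1`), compound 2 (`NC1=NC2(CCOCC2)N(OCCCOc2ccccc2Cl)C(N)=N1`) and compound 3 (`NC1=NC2(CCOCC2)N(OCCCOc2ccc(Cl)cc2Cl)C(N)=N1`). In a functional assay on HepG2 cells (Homo sapiens) for antiproliferative activity, read by MTT assay, with a stated time of 72 h (on this read-out lower numbers stand for stronger inhibition and higher numbers for weaker inhibition), only compound 2 gives a number, at 1750 nM in this small set. Compound 3 has no single number and stands as "not determined" (no result reported) in the record, and compound 1 likewise stands as "not determined" (no result reported) there. Compound 4 (`NC1=NC2(CCOCC2)N(OCCCOc2ccc(Cl)c(Cl)c2)C(N)=N1`) has the same atoms as compound 3, joined differently (3,4-dichlorophenyl in place of 2,4-dichlorophenyl on an oxygen on a saturated carbon), with 3,4-dichlorophenyl in place of 2,4-dichlorophenyl on an oxygen on a saturated carbon. Among the compounds with values here, the only numerical guide is compound 2 at 1750 nM and no step beyond the scatter is expected in this assay from this swap, in either direction. For compound 4 the estimated value is 1500 nM with an expected range from 500 nM to 4500 nM as its upper end.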

Compound 4, half-maximal inhibitory concentration: 380 nM
For compound 4 the middle estimate is 3.9-fold (0.60 log units) above the measured one; the whole stated range lies above it.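

In this assay the aryl group on this oxygen proves able to shift the number: replacing 2-chlorophenyl with 3,4-dichlorophenyl gives a 4.6-fold lower number from compound 2 to compound 4 (0.66 log units; beyond the scatter) and so moves it beyond the scatter. The direct swap from 2,4-dichlorophenyl to 3,4-dichlorophenyl cannot be read, as compound 3 has no single number. Nothing measured here explains the step.

Going by these compounds, whether the added chlorine or its placement carries the step stays open. So does what a nitrile or an amine on this phenyl ring would do.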